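Pyridyl substituent changes on the biaryl alaninamide series

A few compounds are considered here, and "the series" means these few. Any claim that something is new, unique, unknown or untested is made for them only; others in the source may bear on it.

Compound 1 `CCN(CC)C(=O)c1cncc(-c2ccc(C(=O)N[C@@H](C)C(=O)Nc3ccc(Cl)c(C(F)(F)F)c3)cc2)c1`: in a functional assay on K562 cells (Homo sapiens) for inhibition, read by MTT assay, with a stated time of 48 h (on this read-out lower numbers stand for stronger inhibition and higher numbers for weaker inhibition), compound 1 gives 20200 nM.
Compound 2 `C[C@H](NC(=O)c1ccc(-c2ccc(NS(C)(=O)=O)nc2)cc1)C(=O)Nc1ccc(Cl)c(C(F)(F)F)c1`: in this assay compound 2 gives 7240 nM.
Compound 3 `CC(=O)Nc1ccc(-c2ccc(C(=O)N[C@@H](C)C(=O)Nc3ccc(Cl)c(C(F)(F)F)c3)cc2)cn1`: in this assay compound 3 gives 107000 nM.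

Compound 3 stands highest of the three numbers; compound 1 sits below it, and compound 2 lowest. For the measured compounds named here, the one single-point step, a 15-fold higher number from compound 2 to compound 3 (1.17 log units; beyond the scatter), is large and beyond the scatter. Compound 4 `C[C@H](NC(=O)c1ccc(-c2cncc(C(=O)NC3CC3)c2)cc1)C(=O)Nc1ccc(Cl)c(C(F)(F)F)c1` carries 5-(cyclopropylcarbamoyl)pyridin-3-yl in place of 6-acetamidopyridin-3-yl on an aromatic carbon. Going by the values given here, no measured step covers this change directly; the only comparison is that compound 1, bearing a carbamoyl group on the pyridine in the same manner, gives 20200 nM, well under compound 3. Compound 4 is therefore expected to move downward by a 4.9-fold lower number from compound 3 to compound 4 (0.69 log units; beyond the scatter), toward the region of compound 1. The estimate for compound 4 in this assay is 22000 nM, with a range of 6000 nM to 70000 nM.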

Compound 4, half-maximal inhibitory concentration: 396000 nM
Compound 4: the middle estimate sits 18-fold (1.26 log units) below what was measured; measured number outside the range, above it.
By their numbers in this assay, from the lowest: compound 2; then compound 1; then compound 3; then compound 4.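

In this assay, the amine on the carbamoyl carbonyl alone carries a large change: cyclopropylamino in place of diethylamino gives a 20-fold higher number from compound 1 to compound 4 (1.29 log units; beyond the scatter). Swapping the whole substituent for 5-(cyclopropylcarbamoyl)pyridin-3-yl also raises the number, modestly against 6-acetamidopyridin-3-yl (a 3.7-fold higher number from compound 3 to compound 4 (0.57 log units; beyond the scatter)) and largely against 6-(methanesulfonamido)pyridin-3-yl (a 55-fold higher number from compound 2 to compound 4 (1.74 log units; beyond the scatter)), which leaves compound 4 the weakest of the four. No data here bear on the cause of these steps.

Open, from the compounds shown here alone, is whether other amines on that carbonyl, such as dimethylamino or piperidine, fall nearer compound 1 or compound 4. Going by these compounds, a free carboxylic acid in place of the carbamoyl group also remains open.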